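The source may report more compounds than this note shows. Statements on the series, on what has been measured and on what is new or still open speak of the compounds shown alone.

Compound 2, drawn as `COc1ccc(-c2cn3cc(C4=CCN(C(=O)C5CC5)CC4)ccc3n2)cc1OC`, gives 19400 nM in a functional assay on B16-F10 cells (Mus musculus) for antiproliferative activity, read by MTT assay, with a stated time of 48 h (a lower number here means a stronger inhibitor, a higher number a weaker inhibitor), the higher of the two numbers seen so far; its nearest neighbour is compound 1, `COc1ccc(-c2cn3cc(C4=CCN(S(=O)(=O)c5ccccc5)CC4)ccc3n2)cc1OC`, which in this assay gives 13200 nM. Within the data shown here, the single step between them, a 1.5-fold higher number from compound 1 to compound 2 (0.17 log units; within the scatter), exchanges an aryl sulfonyl group for a small carbonyl-linked ring on the amine nitrogen in a ring, and it leaves the read-out essentially where it was.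

Compound 3, `COc1ccc(-c2cn3cc(C4=CCN(C(=O)c5cccc(C(F)(F)F)c5)CC4)ccc3n2)cc1OC`, differs from compound 2 by 3-(trifluoromethyl)phenyl in place of cyclopropyl on a carbonyl carbon. Among the measured compounds shown here, the only measured step that bears on this change is the one from compound 1 to compound 2, and it was within the scatter even though it swapped an aromatic ring for a three-membered one at the same nitrogen. On that slim basis the return of an aromatic ring, now carried on a carbonyl carbon, is not expected to move the number beyond the scatter in this assay, so the step is expected to be a 1.3-fold lower number from compound 2 to compound 3 (0.11 log units; within the scatter). Compound 3 is therefore estimated at 15000 nM, with a plausible range from 5000 nM to 45000 nM.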

Compound 3, half-maximal inhibitory concentration: 7890 nM
For compound 3 the middle estimate is 1.9-fold (0.28 log units) above the measured one; low and high end bracket the measured number.
By their numbers in this assay, from the lowest: compounds 3, 1 and 2 (each within the scatter of the next, the first and the last beyond it).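

In this assay, among these compounds, the group on the carbonyl carbon now proves able to move the read-out: replacing cyclopropyl with 3-(trifluoromethyl)phenyl gives a 2.5-fold lower number from compound 2 to compound 3 (0.39 log units; beyond the scatter) and is the first step here to lie beyond the scatter, though only modestly. The change to a six-membered aromatic ring with 10 heavy atoms, from a three-membered ring with 3, therefore separates two amides that share the same core. Exchanging phenylsulfonyl on the amine nitrogen in a ring for (3-(trifluoromethyl)phenyl)carbonyl gives a 1.7-fold lower number from compound 1 to compound 3 (0.22 log units; within the scatter) and does not separate those two compounds, so only the two carbonyl-linked groups stand apart, and no supporting measurement explains that difference.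

As far as these compounds go, whether the step belongs to the aromatic ring itself or to the trifluoromethyl group on it remains open, and a plain phenyl, or a methoxy group or an amine on that ring in place of trifluoromethyl, would be needed to tell these apart. Also open, from the compounds shown here alone, is whether a longer chain such as butyl on the same carbonyl carbon would read with cyclopropyl or with the aromatic group.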